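Swapping pyrazine for fluorophenyl on a shared amide

A few compounds are considered here, and "the series" means these few. Any claim that something is new, unique, unknown or untested is made for them only; others in the source may bear on it.

Compound 2 `CCN(CC)c1cc2[nH]c(C3CCCCC3)nc2cc1NC(=O)c1cnccn1` carries a pyrazin-2-yl group on its amide carbonyl. In an ADME assay on Vero cells (Chlorocebus sabaeus) for cytotoxicity, read by resazurin assay, with a stated time of 3 days (a higher number here means a weaker inhibitor, a lower number a stronger inhibitor), compound 2 gives > 100 ug/mL, a limit of the assay rather than a number. Compound 1 `CCCCCC(=O)Nc1cc2nc(C3CCCCC3)[nH]c2cc1N1CCCC1` gives > 100 ug/mL in this assay, also a limit. Compound 3 `O=C(CCc1ccccc1)Nc1cc2nc(C3CCCCC3)[nH]c2cc1N1CCCC1` gives > 100 ug/mL in this assay, again a limit. The step that the two limits leave unreadable from compound 1 to compound 3 cannot be read, since all three values sit at the limit of > 100 ug/mL in this assay, at which 3 of the 3 values shown sit. Compound 4 `CCN(CC)c1cc2[nH]c(C3CCCCC3)nc2cc1NC(=O)c1ccc(F)cc1` differs from compound 2 by 4-fluorophenyl in place of pyrazin-2-yl on a carbonyl carbon. Within the data shown here, no measured step bears directly on this change, and the three limits show nothing beyond the scatter. Compound 4 is therefore expected to sit near the same limit, with the step of a number no higher from compound 2 to compound 4 (the limit leaves the size open) expected to be small. The estimate for compound 4 is 100 ug/mL, within 50 ug/mL to 200 ug/mL.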

Compound 4, half-maximal inhibitory concentration: > 100 ug/mL
Compound 4 ended at the assay's limit (the forecaster's own chance of this, stated with the estimate: 75%); the middle value sits exactly at the limit.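

No step can be read between compound 2 and compound 4, because both values are limits rather than numbers: the limit of > 100 ug/mL in this assay, at which 4 of the 4 values shown sit.

The compounds shown leave open whether 4-fluorophenyl in place of pyrazin-2-yl changes cytotoxicity at all.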